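The compounds below may be only part of what the source reports. "The series", "measured", "known", "first", "only" and "open" are said of these compounds alone.

Compound 1 `CN(C)c1ccc(NC(=O)CSc2nc3cccnc3[nH]2)cc1`: 23%
Compound 2 `O=C(CSc1nc2cccnc2[nH]1)Nc1ccc(F)cc1`: 30%
Compound 3 `O=C(CSc1nc2cccnc2[nH]1)Nc1ccccc1F`: 13%

In an assay on isolated protein for inhibition of Ectonucleotide pyrophosphatase/phosphodiesterase family member 1 (Homo sapiens), tested at 10 uM (on this read-out lower numbers stand for less inhibition and higher numbers for more inhibition at the one concentration tested (going by the name of the read-out)), compound 2 has the highest of the three numbers, though compound 1 sits within the scatter of it, as the step of a number 7 percentage points higher from compound 1 to compound 2 (within the scatter) shows; only compound 3 lies clearly apart, with a number 17 percentage points lower from compound 2 to compound 3 (beyond the scatter). Compound 4 `COc1ccc(NC(=O)CSc2nc3cccnc3[nH]2)cc1` differs from compound 2 in one place: methoxy in place of fluoro on an aromatic carbon. Going by the values given here, the one measured step that bears on this change is the exchange of substituents on the same aromatic carbon, a number 7 percentage points higher from compound 1 to compound 2 (within the scatter), which stayed within the scatter. No step beyond the scatter is therefore expected for compound 4 in this assay, with a number 3 percentage points lower from compound 2 to compound 4 (within the scatter). The estimate for compound 4 is 27%, in the range 14% to 40%.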

Compound 4, a percentage reported as inhibition, at one concentration (the size of the read-out at that concentration, not a potency): 48%
Estimate against measurement, compound 4: 21 percentage points below; measured number above the stated range.
By their numbers in this assay, from the lowest: compounds 3, 1 and 2 (each within the scatter of the next, the first and the last beyond it); then compound 4.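

In this assay the aromatic carbon para to a large group turns out to respond to its substituent, since methoxy gives (a number 18 percentage points higher from compound 2 to compound 4 (beyond the scatter)) and also (a number 25 percentage points higher from compound 1 to compound 4 (beyond the scatter)), while fluoro and dimethylamino stayed within the scatter of each other at this place. Methoxy thus stands apart from both earlier groups. Nothing available accounts for this gain.

On these data alone, whether the gain follows the oxygen or the added carbon stays open. So does whether a hydroxy or ethoxy group at this place would keep it.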